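The source may hold more compounds than are shown below. What is called first, only, known or untested is meant among the compounds shown, and "the series" means these compounds.

Three compounds share one core and were read in a functional assay on PC-12 cells (Rattus norvegicus) for cytotoxicity, read by MTT assay, with stated times of 2 h and 24 h, tested at 10 uM; on this read-out higher numbers stand for a stronger effect at the one concentration tested and lower numbers for a weaker effect. Compound 1 `CC(C)(C)c1ccc(-n2nc(-c3ccc(C(F)(F)F)cc3O)nc2-c2ccccc2O)cc1` gives 81.1%. Compound 2 `Oc1cc(C(F)(F)F)ccc1-c1nc(-c2ccccc2O)n(-c2ccccc2Cl)n1` gives 102%. Compound 3 `COc1cccc(-n2nc(-c3ccc(C(F)(F)F)cc3O)nc2-c2ccccc2O)c1` gives 106%, the highest of the three numbers, though its gap to compound 2 lies within the scatter and only compound 1 sits beyond it. Compound 4 `Oc1cc(C(F)(F)F)ccc1-c1nc(-c2ccccc2O)n(-c2ccc(Cl)cc2Cl)n1` differs from compound 3 by 2,4-dichlorophenyl in place of 3-methoxyphenyl on an aromatic nitrogen. All three measured steps swap the group on this aromatic nitrogen: a number 20.9 percentage points higher from compound 1 to compound 2 (beyond the scatter) and a number 24.9 percentage points higher from compound 1 to compound 3 (beyond the scatter) were modest, whereas a number 4 percentage points higher from compound 2 to compound 3 (within the scatter) stayed within the scatter. Compound 2, which bears 2-chlorophenyl there, gives 102%. For compound 4 the expected step is a number 6 percentage points lower from compound 3 to compound 4 (within the scatter), nothing beyond the scatter. Compound 4 is therefore estimated at 100%, between 85% and 115%.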

Compound 4, a percentage reported as activity, at one concentration (the size of the read-out at that concentration, not a potency): 95.2%
The estimate for compound 4 lay 4.8 percentage points above the measured number, within the range that was stated.
By their numbers in this assay, from the lowest: compound 1; then compounds 4, 2 and 3 (each within the scatter of the next, the first and the last beyond it).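

Adding a second chlorine to the 2-chlorophenyl group, chloro in place of hydrogen on an aromatic carbon, gives a number 6.8 percentage points lower from compound 2 to compound 4 (within the scatter), so this change does not separate the two compounds. Yet 2,4-dichlorophenyl in place of 3-methoxyphenyl gives a number 10.8 percentage points lower from compound 3 to compound 4 (beyond the scatter), while 2,4-dichlorophenyl in place of 4-(tert-butyl)phenyl gives a number 14.1 percentage points higher from compound 1 to compound 4 (beyond the scatter), which keeps the 4-(tert-butyl)phenyl compound apart from all three others. Nothing available gives a reason for these steps. Still open, as far as these compounds go, is how a phenyl group carrying an amine or a carboxylic acid, or a longer alkyl chain in place of the phenyl group, would read on this aromatic nitrogen.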